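The source may hold more compounds than are shown below. What is called first, only, known or untested is meant among the compounds shown, and "the series" means these compounds.

In a functional assay on HepG2 cells (Homo sapiens) for cytotoxicity, read by spectrophotometry, with a stated time of 72 h (a lower number here means a stronger inhibitor, a higher number a weaker inhibitor), compound 1 `COc1ccc(-c2cccc(=O)n2-c2cc(OC)c(OC)c(OC)c2)cc1O` gives < 10 nM as a limit and not a number. Among the measured compounds shown here, compound 2 `COc1ccc(-c2cccc(=O)n2-c2cc(OC)c(OC)c(OC)c2)cc1C` gives 129 nM as the only exact number so far. Compound 3 `COc1cc(-n2c(-c3cccc4cc[nH]c34)cccc2=O)cc(OC)c1OC` carries 1H-indol-7-yl in place of 4-methoxy-3-methylphenyl on the shared core, and 1H-indol-7-yl in place of 4-methoxy-3-methylphenyl on an aromatic carbon sets out the difference from compound 2. For the measured compounds named here, the one measured step on this group, large as it was, is an at least 12-fold higher number from compound 1 to compound 2 (1.11 log units; beyond the scatter) and it put only methyl in place of hydroxy, so it gives no direction for exchanging the whole group and the expected change is a 1.3-fold lower number from compound 2 to compound 3 (0.11 log units; within the scatter) with wide uncertainty. For compound 3 the estimated value is 100 nM with an expected range from 15 nM to 700 nM in this assay once measured.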

Compound 3, half-maximal inhibitory concentration: 2400 nM
Compound 3: middle estimate off by 24-fold (1.38 log units), on the low side, and the stated range ends below it.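

Both 1H-indol-7-yl and 4-methoxy-3-methylphenyl hold 9 heavy atoms, yet on this aromatic carbon next to the ring nitrogen the exchange gives a 19-fold higher number from compound 2 to compound 3 (1.27 log units; beyond the scatter), so an equal heavy-atom count does not preserve the value. Measured against the hydroxy compound, the gap is wider still: an at least 240-fold higher number from compound 1 to compound 3 (2.38 log units; beyond the scatter). That step is open-ended, since compound 1 stands at a limit and not a number: the limit of < 10 nM in this assay, at which 1 of the 3 values shown sits.

On these data alone, whether the indole's ring pair or its hydrogen-bond donor drives the loss stays open. So does whether an amine in place of the hydroxy of compound 1 would keep its potency.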